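Cytotoxicity notes: extending the benzylidene of compound 2

This account rests on a few compounds, and the source may have more. Where it says the series, first, only, none or still open, it means among the compounds named here.

Compound 2 `CC(=O)OC[C@H]1O[C@@H](n2cc(CN3C(=O)/C(=C\c4ccccc4)c4ccccc43)nn2)[C@H](OC(C)=O)[C@@H](OC(C)=O)[C@@H]1OC(C)=O` is the reference point. In an ADME assay on NIH3T3 cells (Homo sapiens) for cytotoxicity, read by sulforhodamine B assay, with a stated time of 48 h (a lower number here means a stronger inhibitor, a higher number a weaker inhibitor), compound 2 gives 22800 nM, the lowest of the two numbers in hand. Compound 1 `CC(=O)OC[C@H]1O[C@@H](n2cc(Cn3cc(/C=C4/C(=O)Nc5ccc(F)cc54)c4ccccc43)nn2)[C@H](OC(C)=O)[C@@H](OC(C)=O)[C@@H]1OC(C)=O` gives 62500 nM in this assay. For compound 3 `CC(=O)OC[C@H]1O[C@@H](n2cc(CN3C(=O)/C(=C/c4ccccc4)c4ccccc43)nn2)[C@H](OC(C)=O)[C@@H](OC(C)=O)[C@@H]1OC(C)=O` this assay reports only a limit, > 100000 nM. Among the compounds with values here, the one measured step, an at least 4.3-fold higher number from compound 2 to compound 3 (0.64 log units; beyond the scatter), concerns configuration alone, as noted in the fact that compounds 2 and 3 differ only in the configuration as drawn, and one of its ends is the limit described in the limit of > 100000 nM in this assay, at which 1 of the 3 values shown sits.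

Compound 4 `CC(=O)OC[C@H]1O[C@@H](n2cc(CN3C(=O)/C(=C\C=C\c4ccccc4)c4ccccc43)nn2)[C@H](OC(C)=O)[C@@H](OC(C)=O)[C@@H]1OC(C)=O` differs from compound 2 by 2-phenylethenyl in place of phenyl on a double-bonded chain carbon bound to a double-bonded ring carbon. Within the data shown here, no measured step changes the length of this chain; the step from compound 2 to compound 3 does not bear on it, and the step from compound 2 to compound 1 exchanges the whole core and side chain. In this assay, therefore, the expected step is a 1.3-fold higher number from compound 2 to compound 4 (0.12 log units; within the scatter), which is taken as within the scatter. For compound 4 the estimate in this assay is 30000 nM, with a range from 10000 nM to 100000 nM.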

Compound 4, half-maximal inhibitory concentration: 25900 nM
The estimate for compound 4 lay 1.2-fold (0.06 log units) above the measured number; the range from low to high includes it.
By their numbers in this assay, from the lowest: compounds 2 and 4 (each within the scatter of the next); then compound 1. At a limit, above all of these: compound 3.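

In this assay, within the data shown here, the step of a 1.1-fold higher number from compound 2 to compound 4 (0.06 log units; within the scatter) is the first reading on chain length at this position, on a double-bonded chain carbon bound to a double-bonded ring carbon. The earlier compounds shown here spoke only to configuration at the double bond, whereas this pair shows that 2-phenylethenyl in place of phenyl, with its 1 double bond outside aromatic rings, leaves the number within the scatter. No measurement at hand gives a reason for the size of this step.

Open, going by these compounds, is whether a longer chain, or an amine or a carboxylic acid on the phenyl ring, would keep the number in the same range. Also open, on these data alone, is whether the configuration step seen with phenyl recurs with 2-phenylethenyl.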